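The source may hold more compounds than are shown below. What is called first, only, known or untested is meant among the compounds shown, and "the series" means these compounds.

Working notes on the series: in a functional assay on CCRF-CEM cells (Homo sapiens) for antiproliferative activity, with a stated time of 72 h (on this read-out higher numbers stand for weaker inhibition and lower numbers for stronger inhibition), compound 1 `OC[C@H]1O[C@@H](n2cnc3c(NCc4ccccc4F)ncnc32)[C@H](O)[C@@H]1O` gives 4600 nM, compound 2 `OC[C@H]1O[C@@H](n2cnc3c(NCc4ccccc4Cl)ncnc32)[C@H](O)[C@@H]1O` gives 14500 nM, and compound 3 `OC[C@H]1O[C@@H](n2cnc3c(NCc4cccc(Br)c4)ncnc32)[C@H](O)[C@@H]1O` gives 5000 nM. The data show a 1.1-fold higher number from compound 1 to compound 3 (0.04 log units; within the scatter) and a 2.9-fold lower number from compound 2 to compound 3 (0.46 log units; beyond the scatter), so compound 3 cannot be separated from compound 1 and stands clear of compound 2, the highest number of the three.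

Compound 4 `Cc1cccc(CNc2ncnc3c2ncn3[C@@H]2O[C@H](CO)[C@@H](O)[C@H]2O)c1` is related to compound 3 by methyl in place of bromo on an aromatic carbon, which is methyl in place of bromo on an aromatic carbon, meta to a large group. Among the measured compounds shown here, no measured step makes this exchange. For the measured compounds named here, the closest precedent is the swap of one halogen for another, a 3.2-fold higher number from compound 1 to compound 2 (0.50 log units; beyond the scatter), a modest step. The change of aryl group in a 1.1-fold higher number from compound 1 to compound 3 (0.04 log units; within the scatter) stays within the scatter, and the one in a 2.9-fold lower number from compound 2 to compound 3 (0.46 log units; beyond the scatter) is also modest. A large move in this assay is therefore not expected, and no direction is supported, so no step beyond the scatter is anticipated. The expected step is a 1.2-fold higher number from compound 3 to compound 4 (0.08 log units; within the scatter). For compound 4 the estimated value is 6000 nM, with an expected range of 2500 nM to 15000 nM.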

Compound 4, half-maximal inhibitory concentration: 19100 nM
Compound 4: middle estimate off by 3.2-fold (0.50 log units), on the low side, outside the stated range (above it).
By their numbers in this assay, from the lowest: compounds 1 and 3 (each within the scatter of the next); then compounds 2 and 4 (each within the scatter of the next).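

In this assay the place meta to a large group proves sensitive to the exchange: methyl in place of bromo, one heavy atom for one with no change in donors, acceptors or charge, gives a 3.8-fold higher number from compound 3 to compound 4 (0.58 log units; beyond the scatter) and so separates two compounds that differ only there. Compound 4 also stands clear of compound 1, with a 4.2-fold higher number from compound 1 to compound 4 (0.62 log units; beyond the scatter) beyond the scatter, while a 1.3-fold higher number from compound 2 to compound 4 (0.12 log units; within the scatter) leaves it inseparable from compound 2, so the 3-methylbenzyl compound falls with compound 2 and not with its 3-bromobenzyl partner. Nothing available accounts for this split between bromo and methyl.

From the compounds shown here alone, whether a methoxy group, an amine or a longer chain such as ethyl on the same aromatic carbon would read with bromo or with methyl stays open. Also open, going by these compounds, is whether methyl in place of the halogen of compound 1 or compound 2 would move the number the same way.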